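Rat clearance after replacing the (methylsulfonyl)methyl group

A few compounds are considered here, and "the series" means these few. Any claim that something is new, unique, unknown or untested is made for them only; others in the source may bear on it.

Of the compounds shown here, two have been measured so far in an in vivo ADME assay on the whole organism for pharmacokinetics, with Rattus norvegicus as the target; on this read-out lower numbers stand for slow clearance and higher numbers for fast clearance. Compound 1 `Cc1ncn(-c2ccc(C(=O)Nc3ccc(Cl)c(-c4ccccn4)c3)c(C)n2)n1` gives 0.7 mL/min/kg, and compound 2 `CS(=O)(=O)Cc1ccc(C(=O)Nc2ccc(Cl)c(-c3ccccn3)c2)c(Cl)c1` gives 5.5 mL/min/kg. Compound 2 therefore holds the higher of the two numbers, and its gap to compound 1 lies beyond the usual scatter of repeated measurements.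

Compound 3 `O=C(NCc1ccccn1)c1ccc(C(=O)Nc2ccc(Cl)c(-c3ccccn3)c2)c(Cl)c1` differs from compound 2 in one place: ((pyridin-2-yl)methyl)carbamoyl in place of (methylsulfonyl)methyl on an aromatic carbon. In words, ((pyridin-2-yl)methyl)carbamoyl stands in place of (methylsulfonyl)methyl on an aromatic carbon, meta to a chloro group.

Among the measured compounds shown here, no two measured compounds differ in only one place, so the data do not show directly how far such an exchange moves clearance. For the measured compounds named here, the only guide is the spread between compound 2 at 5.5 mL/min/kg and compound 1 at 0.7 mL/min/kg, and those two differ in more than one place. A moderate rise is expected, just beyond the scatter, but this is a cautious judgement. The expected step is a 2.5-fold higher number from compound 2 to compound 3 (0.41 log units; beyond the scatter). For compound 3 the estimated value is 14 mL/min/kg, with an expected range from 4 mL/min/kg to 40 mL/min/kg.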

Compound 3, clearance in the Rattus norvegicus assay: 6.7 mL/min/kg
The estimate for compound 3 lay 2.1-fold (0.32 log units) above the measured number, and the stated range covers the measured number.
By their numbers in the Rattus norvegicus assay, from the lowest: compound 1; then compounds 2 and 3 (each within the scatter of the next).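

In the Rattus norvegicus assay, the exchange gives a 1.2-fold higher number from compound 2 to compound 3 (0.09 log units; within the scatter), so this position, para to a large group and meta to a chloro group, accepts the larger ((pyridin-2-yl)methyl)carbamoyl group, with its six-membered aromatic ring and hydrogen-bond donor, without a clearance difference that stands out from repeat measurements. Among the compounds shown here, compound 1 and compound 2 differ in more than one place, so this pair is the first to read this single exchange on its own. In a physicochemical assay for solubility, measured as thermodynamic solubility, at pH 1.0 (on this read-out lower numbers stand for lower solubility and higher numbers for higher solubility), compound 2 gives 110 ug/mL and compound 3 gives 4300 ug/mL. In the physicochemical assay the same pair does separate, which shows that at this position solubility can move while clearance stays within the scatter: the measured solubility of compound 2, 110 ug/mL, and of compound 3, 4300 ug/mL, a 39-fold higher number (1.59 log units; beyond the scatter)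

As far as these compounds go, the exchange swaps the whole group at once, so it remains open whether the (pyridin-2-yl)methyl part or the carbamoyl part goes with the solubility difference, and a plain methylcarbamoyl group at this place would help to tell them apart. Also open, from the compounds shown here alone, is where a carboxylic acid or an aminomethyl group at this place would fall in the Rattus norvegicus assay and in the physicochemical assay.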